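Adding a Third Methoxy Group: From Compound 3 to Compound 4

The source may report more compounds than this note shows. Statements on the series, on what has been measured and on what is new or still open speak of the compounds shown alone.

Of the compounds shown here, three have so far been measured in a functional assay on the whole organism (strain Swiss albino) with Mus musculus as the target, in the forced swim test, with a stated time of 5 min, at a dose of 0.5 mg/kg by the intraperitoneal route; a lower number here means less inhibition, a higher number more inhibition at the dose given (going by the name of the read-out). Compound 1 `COc1cc(-c2cc3cc(C4C(C#N)=C(N)OC5=C4C(=O)CC(C)(C)C5)cc(C)c3oc2=O)cc(OC)c1OC` gives 6.37%. Compound 2 `COc1cc(-c2cc3cc(C4C(C#N)=C(N)OC5=C4C(=O)CC(C)(C)C5)cc(C(C)C)c3oc2=O)cc(OC)c1OC` carries an isopropyl group where compound 1 carries a methyl group. In this assay compound 2 gives 29.2%. That single step is a number 22.8 percentage points higher from compound 1 to compound 2 (beyond the scatter). Compound 3 `CCC(C)c1cc(C2C(C#N)=C(N)OC3=C2C(=O)CC(C)(C)C3)cc2cc(-c3ccc(OC)c(OC)c3)c(=O)oc12` gives 57.4%, the highest of the three numbers, standing beyond the scatter above both compound 2 and compound 1.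

Compound 4 `CCC(C)c1cc(C2C(C#N)=C(N)OC3=C2C(=O)CC(C)(C)C3)cc2cc(-c3cc(OC)c(OC)c(OC)c3)c(=O)oc12` has not yet been measured. It differs from compound 3 in one place: methoxy in place of hydrogen on an aromatic carbon. Within the data shown here, the only measured single step, between compound 1 and compound 2, concerns a different part of the molecule, so it does not speak to this change. Among the measured compounds shown here, compound 1 and compound 2 already carry the 3,4,5-trimethoxyphenyl group of compound 4, but each also differs from compound 3 in a second place, so their values show only that those two compounds sit lower than compound 3 without isolating why. For the measured compounds named here, with no direct precedent, the expected step of a number 12.4 percentage points lower from compound 3 to compound 4 (beyond the scatter) is small to moderate, more likely downward than upward, and may not exceed the scatter. Compound 4 is therefore estimated at 45%, with a range from 20% to 68%.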

Compound 4, a percentage reported as inhibition, in the whole organism at one dose (the size of the read-out at that dose, not a potency): 28.2%
For compound 4 the middle estimate is 16.8 percentage points above the measured one; measured number inside the range.
By their numbers in this assay, from the lowest: compound 1; then compounds 4 and 2 (each within the scatter of the next); then compound 3.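

In this assay, among these compounds, with the sec-butyl group held constant, going from 3,4-dimethoxyphenyl to 3,4,5-trimethoxyphenyl gives a number 29.2 percentage points lower from compound 3 to compound 4 (beyond the scatter), the first direct reading of this position, and it shows that one added methoxy group on this ring can cost a clear part of the inhibition. With the 3,4,5-trimethoxyphenyl group held constant, sec-butyl in place of methyl gives a number 21.8 percentage points higher from compound 1 to compound 4 (beyond the scatter), while methyl in place of hydrogen on the saturated chain, the change that turns isopropyl into sec-butyl, gives a number 1 percentage points lower from compound 2 to compound 4 (within the scatter), so the gain over methyl does not grow further in this pair. Nothing measured here accounts for the effect of the added methoxy group.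

Going by these compounds, whether the change at this position depends on methoxy itself stays open, as a hydroxy group, an ethoxy group or a fluorine atom in the same place would show how specific it is. It is also unknown how the 3,4-dimethoxyphenyl group would behave with methyl or isopropyl on the other side, or how a longer chain such as n-pentyl would compare with sec-butyl.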